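Hydroxy added to the core of compound 1

A few compounds are considered here, and "the series" means these few. Any claim that something is new, unique, unknown or untested is made for them only; others in the source may bear on it.

In a functional assay on KB cells (Homo sapiens) for inhibition, read by sulforhodamine B assay (on this read-out lower numbers stand for stronger inhibition of growth and higher numbers for weaker inhibition of growth), compound 1 (`c1ccc(-c2ccc(-c3ccc(-c4nc5ccccc5[nH]4)cc3)cc2)cc1`) gives 39700 nM and sits within the scatter of compound 2 (`FC(F)(F)c1ccc(-c2ccc(-c3ccc(-c4nc5ccccc5[nH]4)cc3)cc2)cc1`), which gives 47200 nM in the same read-out. Compound 3 (`COc1ccc(-c2ccc(-c3ccc(-c4nc5ccccc5[nH]4)cc3)cc2)cc1OC`) gives 9250 nM as the lowest number of the three. Compound 4 (`Oc1cccc2[nH]c(-c3ccc(-c4ccc(-c5ccccc5)cc4)cc3)nc12`) differs from compound 1 by hydroxy in place of hydrogen on an aromatic carbon. Among the measured compounds shown here, two measured steps bear on this only loosely, and neither touches that ring. Trifluoromethyl gives a 1.2-fold higher number from compound 1 to compound 2 (0.08 log units; within the scatter) here, and 3,4-dimethoxyphenyl, which also brings oxygen, gives a 4.3-fold lower number from compound 1 to compound 3 (0.63 log units; beyond the scatter) here. A modest move to a lower number is expected, an estimated 2.2-fold lower number from compound 1 to compound 4 (0.34 log units; beyond the scatter) in this series. Compound 4 is estimated at 18000 nM with an expected range of 6000 nM to 50000 nM in this assay.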

Compound 4, concentration for 50% growth inhibition: 4010 nM
Estimate against measurement, compound 4: 4.5-fold (0.65 log units) above; the measured number lies below the stated range.
By their numbers in this assay, from the lowest: compound 4; then compound 3; then compounds 1 and 2 (each within the scatter of the next).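

In this assay, hydroxy on an aromatic carbon of the six-membered aromatic ring of carbon only, part of the fused system, gives a 9.9-fold lower number from compound 1 to compound 4 (1.00 log units; beyond the scatter), so this ring of the shared core responds to a single added group. The steps from compound 1 to compounds 2 and 3 replaced only the phenyl and gave no reading on this ring. Nothing on hand accounts for the size of this step.

As far as these compounds go, it remains open whether methoxy, an amine or a carboxylic acid on this same carbon would give a similar step. From the compounds shown here alone, it also remains open whether hydroxy on the other carbons of this ring would do so.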